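From butyl to 1-bromoethyl on a carbonyl carbon

The source may report more compounds than this note shows. Statements on the series, on what has been measured and on what is new or still open speak of the compounds shown alone.

Measured in a functional assay on KYSE-450 cells (Homo sapiens) for inhibition, read by MTT assay, with a stated time of 48 h; on this read-out higher numbers stand for weaker inhibition and lower numbers for stronger inhibition:

Compound 1 `C/C=C/C(=O)N(Cc1ccc(OC)c([N+](=O)[O-])c1)c1cc(OC)c(OC)c(OC)c1`: 510 nM
Compound 2 `COc1cc(NCc2ccccc2)cc(OC)c1OC`: > 80000 nM (a limit)
Compound 3 `CCCCC(=O)N(Cc1ccc(OC)c(O)c1)c1cc(OC)c(OC)c(OC)c1`: 300 nM

Compound 2 gives only a limit, > 80000 nM. Compound 3 stands at 300 nM, and compound 1 stands within the scatter of it at 510 nM, so these two numbers cannot be told apart.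

Compound 4 `COc1ccc(CN(C(=O)C(C)Br)c2cc(OC)c(OC)c(OC)c2)cc1O` has not yet been measured. It has 1-bromoethyl in place of butyl on a carbonyl carbon, and the rest of compound 3 stays the same: 1-bromoethyl in place of butyl on a carbonyl carbon. Within the data shown here, no two measured compounds differ in just one place, so this change has no direct precedent. Compound 1 carries a different group at that carbonyl carbon and differs elsewhere too, yet gives 510 nM. On that basis, no step beyond the scatter is expected in this assay. The estimated change is a 1.5-fold lower number from compound 3 to compound 4 (0.18 log units; within the scatter). For compound 4, the expected value is 200 nM, with an estimated range of 40 nM to 1000 nM.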

Compound 4, half-maximal inhibitory concentration: 160 nM
For compound 4 the middle estimate is 1.3-fold (0.10 log units) above the measured one; the measured number falls inside the stated range.
By their numbers in this assay, from the lowest: compounds 4, 3 and 1 (each within the scatter of the next, the first and the last beyond it). At a limit, above all of these: compound 2.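

In this assay, among these compounds, the exchange of butyl for 1-bromoethyl on a carbonyl carbon gives a 1.9-fold lower number from compound 3 to compound 4 (0.27 log units; within the scatter) and is the first comparison at this place with the rest of the molecule held the same. The two compounds therefore cannot be told apart in this assay, so in this one pair the position accepts either group without a step beyond the usual scatter. Nothing measured here bears on why the change has so little effect.

From the compounds shown here alone, whether this place would also accept an amine, a carboxylic acid or a longer chain remains open. Compound 2 gives only a limit of > 80000 nM and differs from the others in more than one place, so it cannot show what the group at this carbonyl carbon contributes.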